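The source may report more compounds than this note shows. Statements on the series, on what has been measured and on what is new or still open speak of the compounds shown alone.

Of the compounds shown here, three of a shared core have been measured in a functional assay on HL-60 cells (Homo sapiens) for inhibition, read by resazurin assay, with a stated time of 72 h; on this read-out higher numbers stand for weaker inhibition and lower numbers for stronger inhibition. Compound 1 `C=CC1C(=O)N(c2cc(OC)c(OC)c(OC)c2)C1c1ccc(OC)cc1` gives 33 nM. Compound 2 `CCOc1ccc(C2C(C3CC3)C(=O)N2c2cc(OC)c(OC)c(OC)c2)cc1` gives 201 nM. Compound 3 `CCOc1ccc(C2CC(=O)N2c2cc(OC)c(OC)c(OC)c2)cc1` gives 88 nM, the second highest of the three numbers, with compound 2 nearest and compound 1 furthest. Among the compounds with values here, the only single step among them runs a 2.3-fold lower number from compound 2 to compound 3 (0.36 log units; beyond the scatter), so taking the cyclopropyl off that saturated ring carbon lowered the number modestly. Compound 4 `C=CC1C(=O)N(c2cc(OC)c(OC)c(OC)c2)C1c1ccc(OCC)cc1` differs from compound 3 by vinyl in place of hydrogen on a saturated ring carbon. Within the data shown here, no measured pair shows exactly this change; compound 1, which carries a vinyl at that position but a methoxy instead of an ethoxy on the aryl group, gives a lower number than compound 3, while the cyclopropyl of compound 2 gave a higher one. Among the measured compounds shown here, because a 2.3-fold lower number from compound 2 to compound 3 (0.36 log units; beyond the scatter) is the only direct step and points the other way, the expected step of a 1.8-fold lower number from compound 3 to compound 4 (0.25 log units; within the scatter) for compound 4 is a modest lowering, leaning on compound 1 at 33 nM. Compound 4 is therefore estimated at 50 nM in this assay, within 20 nM to 130 nM.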

Compound 4, half-maximal inhibitory concentration: 35 nM
For compound 4 the middle estimate is 1.4-fold (0.15 log units) above the measured one, within the range that was stated.
By their numbers in this assay, from the lowest: compounds 1 and 4 (each within the scatter of the next); then compound 3; then compound 2.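

Read in this assay, vinyl in place of hydrogen on this saturated ring carbon now has a direct step with the 4-ethoxyphenyl group held constant (a 2.5-fold lower number from compound 3 to compound 4 (0.40 log units; beyond the scatter)), and it runs opposite to cyclopropyl, whose removal had lowered the number. Vinyl in place of cyclopropyl at the same carbon gives the largest step among these compounds (a 5.7-fold lower number from compound 2 to compound 4 (0.76 log units; beyond the scatter)), so the group on this carbon can move the number in either direction. The methyl that turns the methoxy of the core of compound 1 into an ethoxy stays within the scatter (a 1.1-fold higher number from compound 1 to compound 4 (0.03 log units; within the scatter)), so with vinyl present the two aryl ethers cannot be told apart here.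

Nothing shown explains why vinyl and cyclopropyl part in this way. Going by these compounds, whether an ethyl, a longer chain or an aminomethyl group on this carbon would follow vinyl or cyclopropyl remains open.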